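The compounds below may be only part of what the source reports. "The series", "measured", "known", "first", "only" and "open" are said of these compounds alone.

The compounds measured so far, each in an assay on HEK293 cells for displacement of a labelled ligand from NPC1-like intracellular cholesterol transporter 1 (Homo sapiens); a lower number here means a stronger inhibitor, a higher number a weaker inhibitor:
compound 1 `CC(C)(C)OC(=O)NCCCNC(=O)CN1CN(c2ccccc2)C2(CCN(C(=O)c3ccc(C4CCCCC4)cc3)CC2)C1=O`: 6000 nM
compound 2 `CC(C)(C)OC(=O)NCC1CCCN(C(=O)CN2CN(c3ccccc3)C3(CCN(C(=O)c4ccc(C5CCCCC5)cc4)CC3)C2=O)C1`: 3800 nM
compound 3 `CC(C)(C)OC(=O)NC1CCCN(C(=O)CN2CN(c3ccccc3)C3(CCN(C(=O)c4ccc(C5CCCCC5)cc4)CC3)C2=O)C1`: 4400 nM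

Compound 3 holds the second highest of these three numbers. Its nearest neighbour is compound 2, the difference being a 1.2-fold higher number from compound 2 to compound 3 (0.06 log units; within the scatter); its values against compound 1 lie within the scatter as well, so the three compounds are not separable here.

Compound 4 `CCOC(=O)C1CCCN(C(=O)CN2CN(c3ccccc3)C3(CCN(C(=O)c4ccc(C5CCCCC5)cc4)CC3)C2=O)C1` differs from compound 3 by ethoxycarbonyl in place of (tert-butoxycarbonyl)amino on a saturated ring carbon. Among the measured compounds shown here, the only measured step, from compound 2 to compound 3, also altered the group on this ring carbon and stayed within the scatter; no measured step swaps the group type itself. On that basis the step is expected to be a 1.1-fold higher number from compound 3 to compound 4 (0.06 log units; within the scatter), with compound 4 estimated at 5000 nM, in a range from 2000 nM to 15000 nM.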

Compound 4, half-maximal inhibitory concentration: 4200 nM
The estimate for compound 4 lay 1.2-fold (0.08 log units) above the measured number, and the stated range covers the measured number.
By their numbers in this assay, from the lowest: compounds 2, 4, 3 and 1 (each within the scatter of the next).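

In this assay, ethoxycarbonyl on the saturated ring carbon, a smaller group without the hydrogen-bond donor, reads the same as (tert-butoxycarbonyl)amino (a 1.0-fold lower number from compound 3 to compound 4 (0.02 log units; within the scatter)), so a change of group type, and not only of the group's length, stays within the scatter. The same holds against ((tert-butoxycarbonyl)amino)methyl (a 1.1-fold higher number from compound 2 to compound 4 (0.04 log units; within the scatter)) and against the open chain of compound 1 (a 1.4-fold lower number from compound 1 to compound 4 (0.15 log units; within the scatter)). No evidence on hand accounts for these numbers. The compounds shown leave open whether a free amine or a carboxylic acid on this ring carbon would move the number beyond the scatter.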